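A Chloro Substituent on a Scaffold Tolerated by Vero Cells

This account rests on a few compounds, and the source may have more. Where it says the series, first, only, none or still open, it means among the compounds named here.

Compound 1 `CO[C@@H]1[C@H]2OC(C)(C)O[C@H]2O[C@@H]1C(=O)c1cnc2sc(C(=O)c3ccccc3)cn12`: in an ADME assay on Vero cells (Chlorocebus sabaeus) for cytotoxicity, read by MTT assay, with a stated time of 48 h (a lower number here means that less compound is tolerated, a higher number that more compound is tolerated), compound 1 gives > 400000 nM, a limit of the assay.
Compound 2 `CC(=O)O[C@@H]1[C@H]2OC(C)(C)O[C@H]2O[C@@H]1C(=O)c1cnc2sc(C(=O)c3ccccc3)cn12`: in this assay compound 2 gives > 400000 nM, also a limit.

Compound 2 therefore stands at the limit, and the step that the two limits leave unreadable from compound 1 to compound 2 is unreadable, since both values sit at the limit of > 400000 nM in this assay, at which 2 of the 2 values shown sit. Compound 3 `CC(=O)O[C@@H]1[C@H]2OC(C)(C)O[C@H]2O[C@@H]1C(=O)c1cnc2sc(C(=O)c3ccc(Cl)cc3)cn12` differs from compound 2 by chloro in place of hydrogen on an aromatic carbon. Among the compounds with values here, no measured step touches this phenyl ring; the only step known lies elsewhere and gives no size. Compound 3 is therefore expected to remain at the limit, estimated at 350000 nM, within 150000 nM to 800000 nM. The expected step is an at least 1.1-fold lower number from compound 2 to compound 3 (0.05 log units; that floor lies within the scatter).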

Compound 3, half-maximal cytotoxic concentration: 70000 nM
The estimate for compound 3 lay 5.0-fold (0.70 log units) above the measured number, outside the stated range (below it).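

Compound 1 and compound 2 both stand at a limit of the assay, and the step between them cannot be read. Within the data shown here, the change from phenyl to 4-chlorophenyl gives the first readable step in this assay with an at least 5.7-fold lower number from compound 2 to compound 3 (0.75 log units; beyond the scatter) and so shows that this place on the aromatic ring matters for how much compound the cells tolerate. Chloro alone is enough to bring a value of this series off the limit.

On these data alone, whether a fluoro, a methoxy or an amine at the same place would lower the number as well remains open. So does the size of the same change on compound 1.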